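The compounds below may be only part of what the source reports. "The series", "measured", "known", "first", "only" and "open" are said of these compounds alone.

In a functional assay on U2OS cells for positive allosteric modulation of metabotropic glutamate receptor 5 (Homo sapiens), read by calcium flux, in the presence of a further agent that is not named here (on this read-out higher numbers stand for an effect only at larger amounts of compound and lower numbers for an effect already at smaller amounts), compound 2 `Fc1ccc(-c2noc(C3CCc4c(nnn4-c4ccc(F)nc4)C3)n2)cc1` reaches only a limit of > 25100 nM, not a number. Compound 1 `Fc1ccc(-c2noc(C3CCc4c(nnn4C4CCCC4)C3)n2)cc1`, which carries a different group on the same aromatic nitrogen, gives 398 nM; 31.6 nM (2 entries) in this assay. The change to compound 3 `CN1CCC(n2nnc3c2CCC(c2nc(-c4ccc(F)cc4)no2)C3)CC1` is 1-methylpiperidin-4-yl in place of 6-fluoropyridin-3-yl on an aromatic nitrogen. Among the measured compounds shown here, no measured step covers this change; because compound 1 gives 398 nM; 31.6 nM (2 entries) with a non-aromatic group at that nitrogen, a move toward an effect at smaller amounts, beyond the scatter, is expected. Compound 3 is estimated at 1000 nM in this assay, between 100 nM and 12000 nM, a step of an at least 25-fold lower number from compound 2 to compound 3 (1.39 log units; beyond the scatter).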

Compound 3, half-maximal effective concentration: 3980 nM
The estimate for compound 3 lay 4.0-fold (0.60 log units) below the measured number, and the stated range covers the measured number.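

On this aromatic nitrogen, 1-methylpiperidin-4-yl in place of 6-fluoropyridin-3-yl gives an at least 6.3-fold lower number from compound 2 to compound 3 (0.79 log units; beyond the scatter) in this assay. A non-aromatic six-membered ring with a ring nitrogen thus gives a single number at this position, where the aromatic ring of compound 2 gave only a limit. Compound 3 reads 3980 nM, a higher number than either entry of compound 1, which reads 398 nM; 31.6 nM (2 entries).

As far as these compounds go, what an unsubstituted piperidin-4-yl, a pyridin-3-yl without the fluorine or an open alkyl chain would give on this nitrogen remains open.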